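Phenyl in Place of the Pyrazole at the Amide Nitrogen

This account rests on a few compounds, and the source may have more. Where it says the series, first, only, none or still open, it means among the compounds named here.

Among the compounds with values here, compound 3 `Cc1ccc(OCC(=O)N(Cc2cccs2)c2c(C)n[nH]c2C)cc1` stands lowest of the three numbers so far in an assay on HEK293 cells for agonist activity at transient receptor potential cation channel subfamily M member 8 (Homo sapiens), read by fluorescence and calcium flux, with a stated time of 15 min; a lower number here means that less compound is needed, a higher number that more compound is needed for the effect: in that assay compound 3 gives 0.3 nM. Its nearest neighbour is compound 2 `Cc1ccc(OCC(=O)N(CCO)Cc2cccs2)cc1`, which in this assay gives 900 nM, and the furthest is compound 1 `Cc1ccc(OCC(=O)N(Cc2cccs2)c2cnn(C)c2)cc1`, which gives 63000 nM. Both steps onto compound 3 were large, a 210000-fold lower number from compound 1 to compound 3 (5.32 log units; beyond the scatter) and a 3000-fold lower number from compound 2 to compound 3 (3.48 log units; beyond the scatter), and the remaining step, a 70-fold lower number from compound 1 to compound 2 (1.85 log units; beyond the scatter), is also well beyond the scatter.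

Compound 4 `Cc1ccc(OCC(=O)N(Cc2cccs2)c2ccccc2)cc1` differs from compound 3 in one place: phenyl in place of 3,5-dimethyl-1H-pyrazol-4-yl on an amide-type nitrogen. The 3,5-dimethyl-1H-pyrazol-4-yl group, with its hydrogen-bond donor and acceptor, leaves, and a ring of carbon only with neither enters. The two measured steps onto compound 3 bear on this: compound 1, whose 1-methyl-1H-pyrazol-4-yl group also lacks a hydrogen-bond donor, sits a 210000-fold lower number from compound 1 to compound 3 (5.32 log units; beyond the scatter) away, and compound 2, whose 2-hydroxyethyl group keeps a donor, sits a 3000-fold lower number from compound 2 to compound 3 (3.48 log units; beyond the scatter) away. Neither measured replacement of this group kept the number near that of compound 3. He therefore expects a large step upward for compound 4, a 17000-fold higher number from compound 3 to compound 4 (4.22 log units; beyond the scatter). Compound 4 is expected to give 5000 nM, within a range from 300 nM to 60000 nM.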

Compound 4, half-maximal effective concentration: 23 nM
For compound 4 the middle estimate is 220-fold (2.34 log units) above the measured one; measured number outside the range, below it.
By their numbers in this assay, from the lowest: compound 3; then compound 4; then compound 2; then compound 1.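

Within the data shown here, on the amide-type nitrogen in this assay, a ring of carbon only goes much further than the earlier compounds showed: removing the 3,5-dimethyl-1H-pyrazol-4-yl group in favour of phenyl gives a 77-fold higher number from compound 3 to compound 4 (1.88 log units; beyond the scatter) and so still costs potency, but compound 4 remains second of the four. Phenyl also outperforms both other groups, with a 39-fold lower number from compound 2 to compound 4 (1.59 log units; beyond the scatter) against the 2-hydroxyethyl group and a 2700-fold lower number from compound 1 to compound 4 (3.44 log units; beyond the scatter) against the 1-methyl-1H-pyrazol-4-yl group. A hydrogen-bond donor on this group therefore does not sort the series: compound 3 and compound 2 both carry one yet stand far apart, while compound 4 and compound 1 both lack one and also stand far apart. Nothing available here gives a reason for these differences.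

The compounds shown leave open whether methyl groups on the phenyl ring would bring compound 4 closer to compound 3, as the two methyl groups of the 3,5-dimethyl-1H-pyrazol-4-yl group might suggest. They also leave open how a pyridine or cyclohexyl ring, or an amine on the phenyl ring, would fare at this nitrogen.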